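From 4-chlorobenzyl to 2-fluorobenzyl at the assay limit

The compounds below may be only part of what the source reports. "The series", "measured", "known", "first", "only" and "open" are said of these compounds alone.

In a functional assay on cells (Platelet, Homo sapiens) for inhibition (on this read-out higher numbers stand for weaker inhibition and lower numbers for stronger inhibition), compound 1 (`CCOC(=O)c1ccc(-c2nn(Cc3cccc(Cl)c3)c3ccccc23)cc1`) gives > 10000 nM, which is a limit and not a number. Compound 2 (`CCOC(=O)c1ccc(-c2nn(Cc3ccc(Cl)cc3)c3ccccc23)cc1`) gives > 10000 nM, again only a limit. Among the measured compounds shown here, the series so far therefore rests on (the limit of > 10000 nM in this assay, at which 2 of the 2 values shown sit), and compound 2 has no number from which to step. For the measured compounds named here, the only measured step is a step that the two limits leave unreadable from compound 1 to compound 2, so it offers no size to carry forward.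

Compound 3 (`CCOC(=O)c1ccc(-c2nn(Cc3ccccc3F)c3ccccc23)cc1`) has 2-fluorophenyl in place of 4-chlorophenyl on a saturated chain carbon bound to an aromatic nitrogen, a change counted as 2-fluorophenyl in place of 4-chlorophenyl on a saturated chain carbon bound to an aromatic nitrogen. In this assay any readable change is expected to run toward stronger inhibition, and the estimated move, an at least 3.3-fold lower number from compound 2 to compound 3 (0.52 log units; beyond the scatter), is loosely held, and the result may again be only a limit. The estimate for compound 3 is 3000 nM, with an expected range from 100 nM to 20000 nM.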

Compound 3, half-maximal inhibitory concentration: > 10000 nM
Compound 3 was reported as a limit; the forecaster's own chance of this, stated with the estimate: 50%; middle value at least 3.3-fold (0.52 log units) away from the limit.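

Compound 3 also sits at the limit, so the steps among compound 1, compound 2 and compound 3 cannot be read: the limit of > 10000 nM in this assay, at which 3 of the 3 values shown sit. The compounds shown leave open whether 3-chlorophenyl, 4-chlorophenyl and 2-fluorophenyl differ at all in this assay.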